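The compounds below may be only part of what the source reports. "The series", "measured", "known", "first", "only" and "open" are said of these compounds alone.

In an ADME assay on THP-1 cells (Homo sapiens) for cytotoxicity, read by flow cytometry and propidium iodide staining, with a stated time of 72 h (a higher number here means a weaker inhibitor, a lower number a stronger inhibitor), compound 2 `COc1cccc(-c2oc3ccc(NC(C)=O)cc3c(=O)c2O)c1` gives 50000 nM and compound 3 `CC(=O)Nc1ccc2oc(-c3ccc(F)cc3)c(O)c(=O)c2c1` gives 26000 nM. Among the compounds with values here, these are the only two exact numbers so far, and the gap between them is a 1.9-fold lower number from compound 2 to compound 3 (0.28 log units; within the scatter). Compound 1 `COc1cccc(-c2cc(=O)c3cc(N)ccc3o2)c1` reads > 125000 nM, which is a limit of the assay and not a number.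

Compound 4 `COc1cccc(-c2oc3ccc(N)cc3c(=O)c2O)c1` is compound 2 with hydrogen in place of acetyl on a nitrogen on an aromatic ring, acetamido to amino: hydrogen in place of acetyl on a nitrogen on an aromatic ring. Within the data shown here, no measured step covers this change directly. The nearest guide is the small step between compound 2 and compound 3, at a different place on the molecule, so no step beyond the scatter is expected in this assay. The estimated change is a 1.2-fold higher number from compound 2 to compound 4 (0.08 log units; within the scatter). For compound 4 the expected value is 60000 nM, with an estimated range from 20000 nM to 125000 nM.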

Compound 4, half-maximal inhibitory concentration: 2000 nM
The estimate for compound 4 lay 30-fold (1.48 log units) above the measured number; the measured number lies below the stated range.
By their numbers in this assay, from the lowest: compound 4; then compounds 3 and 2 (each within the scatter of the next). At a limit, above all of these: compound 1.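

Acetamido to amino is a far larger change than the only earlier step, which lay within the scatter at a different place: hydrogen in place of acetyl on the nitrogen gives a 25-fold lower number from compound 2 to compound 4 (1.40 log units; beyond the scatter). With the amino group present in both, hydroxy in place of hydrogen on an aromatic carbon gives an at least 62-fold lower number from compound 1 to compound 4 (1.79 log units; beyond the scatter). The value of compound 1 in that step is a limit and not a number: the limit of > 125000 nM in this assay, at which 1 of the 4 values shown sits.

Only acetyl and hydrogen appear on this nitrogen. As far as these compounds go, how a methyl group, a dimethylamino group or a longer acyl chain there would read remains open.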